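The source may report more compounds than this note shows. Statements on the series, on what has been measured and on what is new or still open speak of the compounds shown alone.

In an assay on cells for displacement of a labelled ligand from Orexin receptor type 2 (Homo sapiens), read by scintillation counting, with stated times of 10 min and 90 min, tested at 10 uM (a higher number here means more inhibition at the concentration tested (going by the name of the read-out), a lower number less inhibition), the three measured compounds gave the following: compound 1 `COC(=O)c1ccc2ccc(C(=O)c3ccc(C(F)(F)F)cc3)c-2cc1` with -47.4%; compound 2 `O=C(O)c1ccc2ccc(C(=O)c3ccc(C(F)(F)F)cc3)c-2cc1` with 1%; compound 3 `COC(=O)c1ccc2ccc(C=O)c-2cc1` with 37.2%.

Compound 2 differs from compound 1 by hydrogen in place of methyl on an oxygen next to a carbonyl group, and that change produced a number 48.4 percentage points higher from compound 1 to compound 2 (beyond the scatter). Compound 3 stands highest of the three, beyond the scatter from both others. How the core of compound 3 differs from the core of compound 1 is not broken down here.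

Compound 4 `O=Cc1ccc2ccc(C(=O)O)ccc1-2` has not been measured in this assay. It differs from compound 3 by hydrogen in place of methyl on an oxygen next to a carbonyl group, the same change at the same place as the one seen earlier. Within the data shown here, because the only earlier example of this change gave a number 48.4 percentage points higher from compound 1 to compound 2 (beyond the scatter), a step in the same direction is expected, estimated as a number 22.8 percentage points higher from compound 3 to compound 4 (beyond the scatter). The expectation rests on a single pair with a different core, so it is held loosely. Compound 4 is estimated at 60%, expected to fall between 25% and 90%.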

Compound 4, a percentage reported as inhibition, at one concentration (the size of the read-out at that concentration, not a potency): 44.1%
Estimate against measurement, compound 4: 15.9 percentage points above, and the stated range covers the measured number.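

In this assay, the change from methoxycarbonyl to carboxy gave a number 6.9 percentage points higher from compound 3 to compound 4 (within the scatter), and the step therefore did not carry over in size from one core to the other: the same change on two cores in this assay, a number 48.4 percentage points higher (beyond the scatter) from compound 1 to compound 2 and a number 6.9 percentage points higher (within the scatter) from compound 3 to compound 4, 41.5 percentage points apart, beyond the scatter of two such steps. The two pairs show that, in this series, the size of this step cannot be assumed to hold on a new core. They do not show what in the cores sets the two steps apart, and two pairs give no rule for any further core.

The compounds shown leave open how an ethyl ester or a longer chain on the same oxygen would read on either core. They also leave open how an amide in place of the carboxy group would read.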